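Oxygen-linked oxane at the nitro-bearing ring: compound 3

The source may hold more compounds than are shown below. What is called first, only, known or untested is meant among the compounds shown, and "the series" means these compounds.

Measured compounds:
compound 1 `CC1(C)CCC(CN2CCN(c3ccc(C(=O)NS(=O)(=O)c4ccc(NCC5CCOCC5)c([N+](=O)[O-])c4)c(Oc4cnc5[nH]ccc5c4)c3)CC2)=C(c2ccc(C(F)(F)F)cc2)C1`, 1.5 nM
compound 2 `CC1(C)CCC(CN2CCN(c3ccc(C(=O)NS(=O)(=O)c4ccc(NC5CCOC5)c([N+](=O)[O-])c4)c(Oc4cnc5[nH]ccc5c4)c3)CC2)=C(c2ccc(C(F)(F)F)cc2)C1`, 1.9 nM

In an assay on isolated protein for displacement of a labelled ligand from Apoptosis regulator Bcl-2 (Homo sapiens), with a stated time of 15 min (on this read-out higher numbers stand for weaker inhibition and lower numbers for stronger inhibition), compound 2 stands as the higher of two numbers, with compound 1 close by; the step of a 1.3-fold higher number from compound 1 to compound 2 (0.10 log units; within the scatter) lies within the scatter. Compound 3 `CC1(C)CCC(CN2CCN(c3ccc(C(=O)NS(=O)(=O)c4ccc(OC5CCOCC5)c([N+](=O)[O-])c4)c(Oc4cnc5[nH]ccc5c4)c3)CC2)=C(c2ccc(C(F)(F)F)cc2)C1` differs from compound 2 by (oxan-4-yl)oxy in place of (oxolan-3-yl)amino on an aromatic carbon. Among the measured compounds shown here, no measured step covers a change of the linking atom, so only the small ring exchange from compound 1 to compound 2 bears on it. Compound 3 is therefore expected to show a modest rise in this assay, a 2.1-fold higher number from compound 2 to compound 3 (0.32 log units; beyond the scatter), with 4 nM estimated between 1.2 nM and 15 nM.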

Compound 3, half-maximal inhibitory concentration: 8.4 nM
Compound 3: middle estimate off by 2.1-fold (0.32 log units), on the low side; measured number inside the range.
By their numbers in this assay, from the lowest: compounds 1 and 2 (each within the scatter of the next); then compound 3.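

In this assay, among the compounds shown here, replacing the amino link with an oxygen-linked oxane gives the first steps at this position that lie beyond the scatter, a 4.4-fold higher number from compound 2 to compound 3 (0.65 log units; beyond the scatter) and a 5.6-fold higher number from compound 1 to compound 3 (0.75 log units; beyond the scatter). The two amino-linked groups had stayed within the scatter of each other, so the position does respond, yet (oxan-4-yl)oxy differs from (oxolan-3-yl)amino in both its linking atom and its ring size. No measured evidence bears on the reason for this rise.

The compounds shown leave open whether the linking oxygen or the six-membered ring carries the step. An (oxan-4-yl)amino group would separate the two.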